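Sulfonamide nitrogen substituent in the bis-sulfonyl piperidine series

The source may hold more compounds than are shown below. What is called first, only, known or untested is meant among the compounds shown, and "the series" means these compounds.

Compound 1 `CCC(CC)S(=O)(=O)c1ccc(S(=O)(=O)N2CCC[C@@H](C(=O)N3CCN(c4nc(C(C)C)no4)CC3)C2)cc1` sets the benchmark: in a functional assay on BXPC-3 cells (Homo sapiens) for inhibition, read by MTT assay, with a stated time of 7 days (a higher number here means a weaker inhibitor, a lower number a stronger inhibitor), compound 1 gives 120 nM. Compound 2 `CCOC(=O)[C@@H]1CCCN(S(=O)(=O)c2ccc(S(=O)(=O)N(CC)CC)cc2C)C1`, with a different core, gives 5600 nM. Compound 3 `CCNS(=O)(=O)c1ccc(S(=O)(=O)N2CCC[C@@H](C(=O)N3CCN(c4nc(C(C)C)no4)CC3)C2)cc1` gives 6900 nM, the highest number of the three; its nearest neighbour is compound 2, within the scatter, while compound 1 lies far below it. For the measured compounds named here, the one measured step that touches compound 3 is a 58-fold higher number from compound 1 to compound 3 (1.76 log units; beyond the scatter), so exchanging the pentan-3-yl on the sulfonyl sulfur for ethylamino costs a great deal.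

Compound 4 `CC(C)c1noc(N2CCN(C(=O)[C@@H]3CCCN(S(=O)(=O)c4ccc(S(=O)(=O)NC5CCC5)cc4)C3)CC2)n1` keeps the sulfonamide of compound 3 and changes only the group on its nitrogen: cyclobutyl in place of ethyl on a sulfonamide nitrogen. Going by the values given here, no measured pair shows this exact change. The step from compound 1 to compound 3 suggests that a bulkier group at this position goes with a lower number, but the sulfonamide nitrogen is retained, so only part of that gain is expected. Compound 4 is therefore expected at 2000 nM, with a range of 600 nM to 7000 nM, a step estimated as a 3.5-fold lower number from compound 3 to compound 4 (0.54 log units; beyond the scatter).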

Compound 4, half-maximal inhibitory concentration: 3300 nM
For compound 4 the middle estimate is 1.7-fold (0.22 log units) below the measured one; low and high end bracket the measured number.
By their numbers in this assay, from the lowest: compound 1; then compounds 4, 2 and 3 (each within the scatter of the next, the first and the last beyond it).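

Working notes on the sulfonamide nitrogen: in this assay, cyclobutyl in place of ethyl moves the number only modestly (a 2.1-fold lower number from compound 3 to compound 4 (0.32 log units; beyond the scatter)), so the group on this nitrogen has some influence, though the step is small. The sulfonamide bearing cyclobutyl remains well short of the benchmark (a 28-fold higher number from compound 1 to compound 4 (1.44 log units; beyond the scatter)), so this change recovers little of the ground lost when the pentan-3-yl on the sulfonyl sulfur is replaced. No supporting evidence bears on why the cyclobutyl group shifts the number.

On these data alone, whether a larger carbon group on this nitrogen, such as cyclohexyl or pentan-3-yl, would narrow the gap remains open. The compounds shown also do not separate the contribution of the sulfonamide nitrogen from that of the group it carries, and a cyclobutyl directly on the sulfonyl sulfur would test this.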